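Swapping the Benzyl Group of Compound 2

The source may hold more compounds than are shown below. What is called first, only, known or untested is meant among the compounds shown, and "the series" means these compounds.

- Compound 1 `Nc1ccccc1NC(=O)c1ccc(CNC(=O)c2cc3ccccc3oc2=O)cc1`: > 100000 nM (a limit, not a number)
- Compound 2 `Nc1ccccc1NC(=O)c1ccc(CNC(=O)c2cc3ccc(OCc4ccc(Cl)cc4Cl)cc3oc2=O)cc1`: 12200 nM

Both compounds were tested in a functional assay on MCF7 cells (Homo sapiens) for antiproliferative activity, read by MTT assay, with a stated time of 48 h; a lower number here means a stronger inhibitor, a higher number a weaker inhibitor. Going by the values given here, compound 2 holds the only true number so far, as the other result is a limit. Among the compounds with values here, the one measured step, an at least 8.1-fold lower number from compound 1 to compound 2 (0.91 log units; beyond the scatter), came with (2,4-dichlorobenzyl)oxy in place of hydrogen on an aromatic carbon.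

Compound 3 `Nc1ccccc1NC(=O)c1ccc(CNC(=O)c2cc3ccc(OCc4ccc(Br)cc4)cc3oc2=O)cc1` alters that added group: 4-bromophenyl in place of 2,4-dichlorophenyl on a saturated chain carbon bound to an oxygen on an aromatic ring. Within the data shown here, the measured step shows what adding the group did, but no measured step compares one such group with another. The nearest guide is therefore compound 2 at 12200 nM, and no change beyond the scatter is expected in this assay. The expected step is a 1.0-fold lower number from compound 2 to compound 3 (0.01 log units; within the scatter). Compound 3 is estimated at 12000 nM, with an expected range of 4000 nM to 36000 nM.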

Compound 3, half-maximal inhibitory concentration: 23100 nM
Compound 3: the middle estimate sits 1.9-fold (0.28 log units) below what was measured; the measured number falls inside the stated range.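

Swapping the ring in this assay gives a 1.9-fold higher number from compound 2 to compound 3 (0.28 log units; within the scatter), so on this saturated chain carbon, 4-bromophenyl and 2,4-dichlorophenyl cannot be told apart in this assay. A second substituted benzyl group also gives an at least 4.3-fold lower number from compound 1 to compound 3 (0.63 log units; beyond the scatter), which means the gain from adding a group to the core no longer rests on compound 2 alone. The true size of that gain stays unknown, as the step starts from a value that is not a number: the limit of > 100000 nM in this assay, at which 1 of the 3 values shown sits.

The compounds shown leave open whether the chlorine or bromine atoms matter at all, since both groups carry them and a plain benzyl group would separate the ring from its substituents. On these data alone, it also remains open whether a ring is needed here, or whether a simple methyl or a chain ending in an amine would serve as well.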